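A few compounds are considered here, and "the series" means these few. Any claim that something is new, unique, unknown or untested is made for them only; others in the source may bear on it.

In an in vivo ADME assay on the whole organism (strain CD1) for pharmacokinetics, with Mus musculus as the target, at a dose of 30 mg/kg by the oral route (a higher number here means more compound in the circulation at the dose given, a lower number less compound in the circulation), compound 1 `CCOC(=O)c1c(-c2cccc(OC)c2)[nH]c2cc(OC)ccc2c1=O` reaches 8000 nM. Among the measured compounds shown here, compound 2 `CCOC(=O)c1c(-c2cccc(OCC)c2)[nH]c2cc(OC)ccc2c1=O` reaches 1900 nM, the lower of the two numbers so far. Compound 3 `CCCOc1cccc(-c2[nH]c3cc(OC)ccc3c(=O)c2C(=O)OCC)c1` keeps the shared core of compound 2 but turns its ethoxy group into propoxy: methyl in place of hydrogen on a saturated chain carbon, two bonds along the chain from an oxygen on an aromatic ring. For the measured compounds named here, only one measured step bears on this change. Methyl in place of hydrogen on a saturated chain carbon bound to an oxygen on an aromatic ring gave a 4.2-fold lower number from compound 1 to compound 2 (0.62 log units; beyond the scatter), a modest step. One step sets no trend, and the new methyl sits at a different place on the chain, so its size carries over only loosely. The expected change is a 2.7-fold lower number from compound 2 to compound 3 (0.43 log units; beyond the scatter), in the same direction but somewhat smaller. For compound 3 the estimated value is 700 nM, with an expected range from 200 nM to 2500 nM.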

Compound 3, maximal plasma concentration: 300 nM
Beside the measured number, compound 3's estimate is 2.3-fold (0.37 log units) above it; the measured number falls inside the stated range.
By their numbers in this assay, from the lowest: compound 3; then compound 2; then compound 1.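

In this assay, adding one more carbon to the chain goes the same way as the earlier change, with a 6.3-fold lower number from compound 2 to compound 3 (0.80 log units; beyond the scatter). What had been a single step is now a run of two in one direction, and across the three compounds none goes against the fall in the number as the chain grows from methoxy through ethoxy to propoxy. Read end to end, the two modest steps add up to a large one, a 27-fold lower number from compound 1 to compound 3 (1.43 log units; beyond the scatter), yet nothing shown explains why the number falls with chain length.

As far as these compounds go, whether the fall continues with a longer chain such as butoxy, or holds for a branched one such as isopropoxy, stays open. So does what an amine or a carboxylic acid would do in place of the propyl group.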